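Working notes: replacing the aryl-bearing group on the chain carbon

This account rests on a few compounds, and the source may have more. Where it says the series, first, only, none or still open, it means among the compounds named here.

In a functional assay for inhibition, with Homo sapiens as the target (on this read-out lower numbers stand for tighter binding and higher numbers for weaker binding), compound 1 `COc1ccc(OC(C)(C)C2OCC(C/C=C\CCC(=O)O)C(c3cccnc3)O2)cc1` gives 302 nM and compound 2 `Cc1ccc(SC(C)(C)C2OCC(C/C=C\CCC(=O)O)C(c3cccnc3)O2)c([N+](=O)[O-])c1` gives 158 nM, two values within the scatter of each other. Compound 3 `CC(C)(Cc1ccc(F)cc1C#N)C1OCC(C/C=C\CCC(=O)O)C(c2cccnc2)O1` is not yet measured and differs from compound 2 as follows: a group of 10 heavy atoms (8 carbon, 1 nitrogen, 1 fluorine; one six-membered aromatic ring of carbon only) in place of a group of 11 heavy atoms (7 carbon, 1 nitrogen, 2 oxygen, 1 sulfur; one six-membered aromatic ring of carbon only), on a saturated chain carbon bound to two saturated chain carbons and a saturated ring carbon. Going by the values given here, the only measured step at this place is a 1.9-fold lower number from compound 1 to compound 2 (0.28 log units; within the scatter), and it lies within the scatter. On that single step, no shift beyond the scatter is expected in this assay. The estimated step is a 1.3-fold higher number from compound 2 to compound 3 (0.10 log units; within the scatter). For compound 3 the expected value is 200 nM, with an estimated range of 70 nM to 550 nM.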

Compound 3, dissociation constant: 2.19 nM
Estimate against measurement, compound 3: 91-fold (1.96 log units) above, and the stated range ends above it.
By their numbers in this assay, from the lowest: compound 3; then compounds 2 and 1 (each within the scatter of the next).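

In this assay, the saturated chain carbon bound to two saturated chain carbons and a saturated ring carbon proves highly sensitive to the attached group, with a 72-fold lower number from compound 2 to compound 3 (1.86 log units; beyond the scatter) and a 140-fold lower number from compound 1 to compound 3 (2.14 log units; beyond the scatter), a change the earlier pair did not reveal. The group of 10 heavy atoms differs from both groups it replaces in its linking atom and its ring substituents together. Nothing available explains the change. Still open, as far as these compounds go, is which of these differences carries the step, and whether a carbon-linked benzene ring bearing only the nitrile or only the fluorine would match compound 3.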